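Aryl variation on the enone series: compound 3 to compound 4

The source may report more compounds than this note shows. Statements on the series, on what has been measured and on what is new or still open speak of the compounds shown alone.

Three close analogues share one core and differ only in the aryl group on the enone. Compound 1 `Cc1c(C(=O)/C=C/c2cccc([N+](=O)[O-])c2)[n+]([O-])c2ccccc2[n+]1[O-]` carries a nitro-substituted phenyl, compound 2 `COc1ccc(/C=C/C(=O)c2c(C)[n+]([O-])c3ccccc3[n+]2[O-])cc1OC` a dimethoxyphenyl and compound 3 `Cc1c(C(=O)/C=C/c2ccc(Cl)c(Cl)c2)[n+]([O-])c2ccccc2[n+]1[O-]` a 3,4-dichlorophenyl. In a functional assay on CCRF-CEM cells (Homo sapiens) for inhibition, with a stated time of 3 days (on this read-out lower numbers stand for stronger inhibition and higher numbers for weaker inhibition), compound 1 gives 15800 nM, compound 2 gives 19200 nM and compound 3 gives 15400 nM. Compound 3 holds the lowest of the three numbers, yet its nearest neighbour is compound 1 and its furthest is compound 2, and both gaps sit within the scatter of the method; the three aryl groups therefore give numbers that cannot be told apart.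

The next member, compound 4 `Cc1c(C(=O)/C=C/c2ccc(Br)cc2)[n+]([O-])c2ccccc2[n+]1[O-]`, is reached from compound 3 by a single change: 4-bromophenyl in place of 3,4-dichlorophenyl on a double-bonded chain carbon bound to a double-bonded chain carbon. Within the data shown here, no measured pair shows a step of this kind, so the expectation rests on the narrow spread of the three numbers.

Because compound 1 gives 15800 nM, compound 2 gives 19200 nM and compound 3 gives 15400 nM in this assay, no step beyond the scatter is expected from compound 3 to compound 4, and the estimated step is a 1.1-fold higher number from compound 3 to compound 4 (0.04 log units; within the scatter). For compound 4 in this assay the estimate is 17000 nM, with a range from 8000 nM to 36000 nM.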

Compound 4, half-maximal inhibitory concentration: 11600 nM
For compound 4 the middle estimate is 1.5-fold (0.17 log units) above the measured one; low and high end bracket the measured number.
By their numbers in this assay, from the lowest: compounds 4, 3, 1 and 2 (each within the scatter of the next).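

In this assay, among these compounds, 4-bromophenyl in place of 3,4-dichlorophenyl on a double-bonded chain carbon bound to a double-bonded chain carbon gives a 1.3-fold lower number from compound 3 to compound 4 (0.12 log units; within the scatter), the only step read between two compounds that differ in one place. The change replaces two chlorine atoms with one bromine atom, while the six-membered aromatic ring of carbon stays and neither group carries a hydrogen-bond donor or acceptor; at this position, that exchange does not move the number beyond the scatter. Nothing at hand bears on what lies behind this result.

Among the compounds shown here, the single step changes both the identity and the number of the halogen atoms, so it leaves open whether either alone would matter; a 4-chlorophenyl or an unsubstituted phenyl at the same place would be needed to tell the two apart. Also open is whether any group here can produce a step beyond the scatter, since all the aryl groups shown are substituted phenyls and the series offers no phenyl bearing an amine or a carboxylic acid.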